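Series notes: from compound 3 to compound 4

The compounds below may be only part of what the source reports. "The series", "measured", "known", "first", "only" and "open" are said of these compounds alone.

Among the compounds with values here, compound 3 `O=C(COc1cc(=O)oc2cc(OCc3cccc(Cl)c3)ccc12)N1CCCCC1` sits at the top of the numbers so far: in an assay on isolated protein (strain Sprague-Dawley) for inhibition of Amine oxidase [flavin-containing] B (Rattus norvegicus), read by spectrophotometry, with a stated time of 5 min (a lower number here means a stronger inhibitor, a higher number a weaker inhibitor), compound 3 gives 38900 nM. Compound 1 `COc1cc(=O)oc2cc(OCc3cccc(Br)c3)ccc12` gives 5.75 nM and compound 2 `NC(=O)COc1cc(=O)oc2cc(OCc3cccc(Br)c3)ccc12` gives 8.91 nM, both far below compound 3. Within the data shown here, the only single-change step measured within the set, a 1.5-fold higher number from compound 1 to compound 2 (0.19 log units; within the scatter), shows that a carbamoyl added on that chain leaves the number essentially where it was. Among the measured compounds shown here, no single-change step connects compound 3 to compound 1 or compound 2, so for those pairs only the gap between the values is known, and that gap is very large in both cases.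

Compound 4 `O=Cc1cc(=O)oc2cc(OCc3cccc(Cl)c3)ccc12` is reached from compound 3 by formyl in place of ((piperidin-1-yl)carbonyl)methoxy on an aromatic carbon. The measured step of a 1.5-fold higher number from compound 1 to compound 2 (0.19 log units; within the scatter) does not describe this exchange, so it bears on it only loosely: it says that small additions on the chain at this position change little, whereas the group of 10 heavy atoms in compound 3 accompanies the highest value of the three. With that group gone and a formyl of 2 heavy atoms in its place, a large fall is expected, a 1300-fold lower number from compound 3 to compound 4 (3.11 log units; beyond the scatter), with the landing point uncertain since compound 4 also lacks the oxygen bound to the aromatic ring seen in compounds 1 and 2. Compound 4 is estimated at 30 nM, with a range from 3 nM to 300 nM.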

Compound 4, half-maximal inhibitory concentration: 52.5 nM
The estimate for compound 4 lay 1.8-fold (0.24 log units) below the measured number; the measured number falls inside the stated range.
By their numbers in this assay, from the lowest: compounds 1 and 2 (each within the scatter of the next); then compound 4; then compound 3.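

In this assay, the exchange of ((piperidin-1-yl)carbonyl)methoxy for formyl, on the aromatic carbon opposite the ring oxygen, gives a 740-fold lower number from compound 3 to compound 4 (2.87 log units; beyond the scatter). Within the data shown here, this is the first single-change step that lies beyond the scatter, and it shows that the group on this carbon can move the number a long way, which the small carbamoyl step on the chain of compounds 1 and 2 could not show. The exchange removes several features together, namely a group of 10 heavy atoms with its six-membered non-aromatic ring and the oxygen bound to the aromatic ring, and nothing available explains the size of the step or assigns it to any one of these features.

Still open, as far as these compounds go, is how much of the step belongs to the piperidine ring, the linking oxygen or the overall size of the group, a question that a carboxylic acid, a hydroxymethyl or an amine on this same carbon would help to divide. Also open, from the compounds shown here alone, is whether a step of this size recurs when bromine stands in place of chlorine on the shared core.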